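Trading the Phenyl for a Chloro on the Benzyl Ring

A few compounds are considered here, and "the series" means these few. Any claim that something is new, unique, unknown or untested is made for them only; others in the source may bear on it.

Compound 3 `O=S(=O)(NCCCNCc1ccc(-c2ccccc2)cc1)c1cc(C(F)(F)F)cc(C(F)(F)F)c1` was tested in a functional assay on BXPC-3 cells (Homo sapiens) for inhibition, read by MTT assay, with a stated time of 72 h (on this read-out higher numbers stand for weaker inhibition of growth and lower numbers for stronger inhibition of growth), where compound 3 gives 1700 nM. Among the three measured compounds it stands second highest. Compound 1 `O=S(=O)(NCCCNCc1ccc(Cl)c(Cl)c1)c1cc(C(F)(F)F)cc(C(F)(F)F)c1` lies closest: in this assay compound 1 gives 1400 nM, and the two values sit within the scatter of each other. Compound 2 `CN(CCCNS(=O)(=O)c1cc(C(F)(F)F)cc(C(F)(F)F)c1)Cc1ccccc1` lies furthest away; in this assay compound 2 gives 39000 nM. Among the measured compounds shown here, the only step between measured compounds that differ in one place is a 28-fold higher number from compound 1 to compound 2 (1.44 log units; beyond the scatter).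

Compound 4 `O=S(=O)(NCCCNCc1ccc(Cl)cc1)c1cc(C(F)(F)F)cc(C(F)(F)F)c1` differs from compound 3 by chloro in place of phenyl on an aromatic carbon. For the measured compounds named here, no measured step swaps exactly these two groups. The step from compound 1 to compound 2 alters a different part of the molecule, so it bears on this change only loosely. What does bear on it is that compound 1, which carries chloro groups rather than a phenyl, and compound 3 give numbers within the scatter of each other. Compound 4 is therefore expected to move little, and the step of a 1.2-fold higher number from compound 3 to compound 4 (0.07 log units; within the scatter) is estimated to stay within the scatter. Compound 4 is expected to give about 2000 nM in this assay, with a range from 700 nM to 6000 nM.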

Compound 4, concentration for 50% growth inhibition: 1600 nM
Beside the measured number, compound 4's estimate is 1.3-fold (0.10 log units) above it; measured number inside the range.
By their numbers in this assay, from the lowest: compounds 1, 4 and 3 (each within the scatter of the next); then compound 2.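

In this assay the swap of chloro for phenyl on this aromatic carbon gives a 1.1-fold lower number from compound 3 to compound 4 (0.03 log units; within the scatter) and so replaces a ring of six heavy atoms with a single atom without any change beyond the scatter, which shows that the outer phenyl ring is not needed to hold this level of growth inhibition. The second chloro of compound 1 can also go, since hydrogen in its place gives a 1.1-fold higher number from compound 1 to compound 4 (0.06 log units; within the scatter) and a single chloro on the benzyl ring serves as well as two in this assay, whereas the large gap remains at the amine end with a 24-fold lower number from compound 2 to compound 4 (1.39 log units; beyond the scatter) for (4-chlorobenzyl)amino in place of benzyl(methyl)amino. That last step changes both the methyl on the nitrogen and the chloro on the ring, and no measurement offered here explains any of these results.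

The compounds shown therefore leave open which of those two changes carries the large step, a question that the plain benzylamino compound or the 4-chlorobenzyl compound with a methyl on the nitrogen could settle. They also leave open whether a group such as methoxy, nitrile or a carboxylic acid would be tolerated at this aromatic carbon as well as chloro and phenyl are.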